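The compounds below may be only part of what the source reports. "The series", "measured", "known", "first", "only" and "open" are said of these compounds alone.

In a functional assay on HCT-116 cells (Homo sapiens) for antiproliferative activity, read by MTT assay, with a stated time of 48 h (on this read-out higher numbers stand for weaker inhibition and lower numbers for stronger inhibition), compound 1 `COc1cc(N(Cc2ccc(C)cc2)C(=O)CSc2nc3ccccc3s2)cc(OC)c1OC` reports only a limit, > 80000 nM. Compound 2 `COc1ccc(CN(C(=O)CSc2nc3ccccc3s2)c2cc(OC)c(OC)c(OC)c2)cc1O` gives 182 nM, and compound 3 `COc1ccc2nc(SCC(=O)N(Cc3ccc(OC)c(O)c3)c3cc(OC)c(OC)c(OC)c3)sc2c1` gives 352 nM. These two values lie within the scatter of each other, and the large step of an at least 430-fold lower number from compound 1 to compound 2 (2.64 log units; beyond the scatter) came from installing 3-hydroxy-4-methoxyphenyl, which compound 4 `COc1ccc(CN(C(=O)CSc2nc3cc(Cl)ccc3s2)c2cc(OC)c(OC)c(OC)c2)cc1O` keeps. Compound 4 instead carries 5-chloro-1,3-benzothiazol-2-yl in place of 6-methoxy-1,3-benzothiazol-2-yl on a sulfur. The closest guide is the added methoxy on this same group, which gave only a 1.9-fold higher number from compound 2 to compound 3 (0.29 log units; within the scatter). A step beyond the scatter is therefore not expected, and the estimated step is a 1.4-fold lower number from compound 3 to compound 4 (0.15 log units; within the scatter). For compound 4 the expected value is 250 nM, within an estimated range of 80 nM to 800 nM.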

Compound 4, half-maximal inhibitory concentration: 429 nM
The estimate for compound 4 lay 1.7-fold (0.23 log units) below the measured number, within the range that was stated.
By their numbers in this assay, from the lowest: compounds 2, 3 and 4 (each within the scatter of the next, the first and the last beyond it). At a limit, above all of these: compound 1.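

In this assay the swap of 6-methoxy-1,3-benzothiazol-2-yl for 5-chloro-1,3-benzothiazol-2-yl on the sulfur gives a 1.2-fold higher number from compound 3 to compound 4 (0.09 log units; within the scatter) and so separates these two substituted groups by no real margin. Chloro in place of hydrogen gives a 2.4-fold higher number from compound 2 to compound 4 (0.37 log units; beyond the scatter) and is the first modest loss beyond the scatter from a change on this group, while compound 3 stays within the scatter of both neighbours. Nothing measured here gives a reason for these shifts. Still open, going by these compounds, is how an amine or a carboxylic acid on the same group would fare.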